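This account rests on a few compounds, and the source may have more. Where it says the series, first, only, none or still open, it means among the compounds named here.

Measured compounds:
Compound 1, `COc1ncnc(Nc2ccc(Cl)c(OCC=C(C)C)c2)n1`: 18000 nM
Compound 2, `CC(C)=CCOc1cc(Nc2ncnc(N)n2)ccc1Cl`: 48000 nM
Compound 3, `COc1ncnc(Nc2ccc(C#N)c(OCC=C(C)C)c2)n1`: 42000 nM

In an ADME assay on MT2 cells (Homo sapiens) for cytotoxicity (a higher number here means that more compound is tolerated, a lower number that less compound is tolerated), the three measured compounds lie fairly close together. Compound 1 gives 18000 nM, and the change to compound 2, (amino in place of methoxy on an aromatic carbon), moves the number by a 2.7-fold higher number from compound 1 to compound 2 (0.43 log units; beyond the scatter). A different change on the other ring, from compound 1 to compound 3, (cyano in place of chloro on an aromatic carbon), gives a 2.3-fold higher number from compound 1 to compound 3 (0.37 log units; beyond the scatter). Compound 2 and compound 3 are within the usual scatter of each other, so no order between them is claimed here.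

Compound 4, `CC(C)=CCOc1cc(Nc2ncnc(N)n2)ccc1C#N`, has not been measured in this assay. It is related to compound 3 by amino in place of methoxy on an aromatic carbon, which is the same change as that from compound 1 to compound 2: the place lines of the two changes agree word for word. The cores of compound 3 and compound 1, on which the change is made, differ as described by cyano in place of chloro on an aromatic carbon.

Because the same change gave a 2.7-fold higher number from compound 1 to compound 2 (0.43 log units; beyond the scatter), the step from compound 3 to compound 4 is expected to be of similar size, estimated at a 2.3-fold higher number from compound 3 to compound 4 (0.35 log units; beyond the scatter). This rests on a single earlier occurrence of the change, on a core that differs in the way noted, so the range is kept wide. For compound 4 in this assay the estimate is 95000 nM, with a range from 45000 nM to 200000 nM.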

Compound 4, half-maximal cytotoxic concentration: 200 nM
Estimate against measurement, compound 4: 480-fold (2.68 log units) above; measured number outside the range, below it.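

In this assay, amino in place of methoxy on an aromatic carbon did not carry over from one core to the other: on the cyano core it gives a 210-fold lower number from compound 3 to compound 4 (2.32 log units; beyond the scatter), opposite in direction to the earlier step and far larger, as this comparison sets out: the same change on two cores in this assay, a 2.7-fold higher number (0.43 log units; beyond the scatter) from compound 1 to compound 2 and a 210-fold lower number (2.32 log units; beyond the scatter) from compound 3 to compound 4, 560-fold (2.75 log units) apart, beyond the scatter of two such steps

Cyano in place of chloro on an aromatic carbon likewise depends on its core, giving a 240-fold lower number from compound 2 to compound 4 (2.38 log units; beyond the scatter) where the amino group is present, and the earlier step on the methoxy core points the other way: the same change on two cores in this assay, a 2.3-fold higher number (0.37 log units; beyond the scatter) from compound 1 to compound 3 and a 240-fold lower number (2.38 log units; beyond the scatter) from compound 2 to compound 4, 560-fold (2.75 log units) apart, beyond the scatter of two such steps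

For the compounds shown here, this shows that the two changes do not add up, since the sharp fall appears only in compound 4, the one compound of the four that carries both the amino and the cyano group, but it does not show why, and each change rests on just one pair of cores.

Still open, going by these compounds, is whether a methylamino group in place of the amino, or a bromo or trifluoromethyl group in place of the cyano, would also give a number as low as that of compound 4 at 200 nM. Also open, on these data alone, is whether that low number depends on the ether chain shared by all four compounds, which a shorter or longer chain there could test.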